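From 4-hydroxyphenyl to 3-(trifluoromethyl)phenyl on a shared core

The source may hold more compounds than are shown below. What is called first, only, known or untested is meant among the compounds shown, and "the series" means these compounds.

Compound 1 `Cc1ccc(/N=C2\C(=O)Nc3ccc(S(=O)(=O)N4CCOCC4)cc32)cc1` gives 309000 nM
Compound 2 `O=C1Nc2ccc(S(=O)(=O)N3CCOCC3)cc2/C1=N/c1ccc(O)cc1` gives 259000 nM

Both numbers come from an ADME assay on WI-38 cells (Homo sapiens) for cytotoxicity, read by sulforhodamine B assay, with a stated time of 24 h (on this read-out lower numbers stand for stronger inhibition and higher numbers for weaker inhibition), and sit so close that compound 2 cannot be told apart from compound 1. Compound 2 is the starting point for the next change. Compound 3 `O=C1Nc2ccc(S(=O)(=O)N3CCOCC3)cc2/C1=N/c1cccc(C(F)(F)F)c1` keeps the shared core but carries 3-(trifluoromethyl)phenyl in place of 4-hydroxyphenyl on a double-bonded nitrogen and has not yet been measured. Among the measured compounds shown here, the one measured step in this set is hydroxy in place of methyl on an aromatic carbon, which gave a 1.2-fold lower number from compound 1 to compound 2 (0.08 log units; within the scatter) and so shows no real change. For the measured compounds named here, no measured compound carries trifluoromethyl, which makes this single step a thin guide. No shift beyond the scatter is therefore expected in this assay for this swap. The estimate means a 1.1-fold lower number from compound 2 to compound 3 (0.03 log units; within the scatter) as the expected step. Compound 3 is expected at 240000 nM with 100000 nM to 450000 nM as its likely range.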

Compound 3, half-maximal inhibitory concentration: 226000 nM
Compound 3: the middle estimate sits 1.1-fold (0.03 log units) above what was measured; the range from low to high includes it.
By their numbers in this assay, from the lowest: compounds 3, 2 and 1 (each within the scatter of the next).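

Among the compounds shown here, on this assay, the swap at this position is larger than the earlier one: the whole group on the double-bonded nitrogen changes, not just one substituent on its aromatic ring, and trifluoromethyl appears for the first time. Exchanging 4-hydroxyphenyl, with its hydrogen-bond donor and acceptor, for 3-(trifluoromethyl)phenyl, which has neither, gives a 1.1-fold lower number from compound 2 to compound 3 (0.06 log units; within the scatter), and exchanging 4-methylphenyl for the same group gives a 1.4-fold lower number from compound 1 to compound 3 (0.14 log units; within the scatter), so neither swap moves the number beyond the scatter. Nothing available explains this lack of response.

On these data alone, it remains open whether the cytotoxicity read-out would stay this flat with an amine or a carboxylic acid on the aromatic ring. Also open, as far as these compounds go, is whether a simple alkyl chain on the double-bonded nitrogen, in place of the aromatic ring, would behave the same way.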